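The compounds below may be only part of what the source reports. "The series", "measured", "known", "first", "only" and "open" are said of these compounds alone.

Measured in a functional assay on HT-29 cells (Homo sapiens) for antiproliferative activity, read by sulforhodamine B assay, with a stated time of 48 h; on this read-out lower numbers stand for stronger inhibition and higher numbers for weaker inhibition:
compound 1 `O=C1NCCN1c1ccc(S(=O)(=O)Nc2ccc(F)cc2)cc1`: 370 nM
compound 2 `CCc1ccc(NS(=O)(=O)c2ccc(N3CCNC3=O)cc2)cc1`: 660 nM
compound 3 `O=C1NCCN1c1ccc(S(=O)(=O)Nc2ccc(Cl)cc2)cc1`: 220 nM

Compound 3 stands at the low end of the three numbers. Two measured steps lead to it: a 1.7-fold lower number from compound 1 to compound 3 (0.23 log units; within the scatter), and a 3.0-fold lower number from compound 2 to compound 3 (0.48 log units; beyond the scatter).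

The next change gives compound 4 `O=C1NCCN1c1ccc(S(=O)(=O)Nc2ccc(OC(F)F)cc2)cc1`, with difluoromethoxy in place of chloro on an aromatic carbon, para to a large group: difluoromethoxy in place of chloro on an aromatic carbon.

All three measured steps fall at this same place, so all bear on the change. The third is a 1.8-fold higher number from compound 1 to compound 2 (0.25 log units; within the scatter). Going by the values given here, only the step to compound 3 from the ethyl compound exceeds the scatter, and no measured compound carries difluoromethoxy, so the read-across is loose. In this assay a step within the scatter is expected, leaning towards a higher number, as compound 3 already sits at the low end with 220 nM.

The expected change is a 1.6-fold higher number from compound 3 to compound 4 (0.20 log units; within the scatter).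

For compound 4 the estimated value is 350 nM, with an expected range of 130 nM to 900 nM.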

Compound 4, half-maximal inhibitory concentration: 650 nM
Beside the measured number, compound 4's estimate is 1.9-fold (0.27 log units) below it, within the range that was stated.
By their numbers in this assay, from the lowest: compounds 3, 1, 4 and 2 (each within the scatter of the next, the first and the last beyond it).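

In this assay, replacing chloro with difluoromethoxy on this aromatic carbon gives a 3.0-fold higher number from compound 3 to compound 4 (0.47 log units; beyond the scatter) and so shows that a change at this position can exceed the scatter in the upward direction from chloro. Difluoromethoxy does not separate from the other two groups, with a 1.0-fold lower number from compound 2 to compound 4 (0.01 log units; within the scatter) and a 1.8-fold higher number from compound 1 to compound 4 (0.24 log units; within the scatter) both within the scatter, so compound 3 now stands apart from compound 2 and compound 4 but not from compound 1. No measurement offers an explanation for this difference between chloro and difluoromethoxy.

From the compounds shown here alone, whether bromo, methoxy or an amine at this position would read with chloro or with difluoromethoxy remains open. Also open, going by these compounds, is whether the same exchange would give a step of similar size on a different core.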